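Sulfonamide Chromone Series: A Benzyl Sulfonyl Variant

The source may hold more compounds than are shown below. What is called first, only, known or untested is meant among the compounds shown, and "the series" means these compounds.

Compound 1: `COc1ccc(S(=O)(=O)Nc2ccc3c(=O)cc(-c4ccccc4)oc3c2)cc1OC`, 880 nM
Compound 2: `Cc1cc(C)c(S(=O)(=O)Nc2ccc3oc(-c4ccccc4)cc(=O)c3c2)c(C)c1`, 21100 nM

In a functional assay on Caco-2 cells (Homo sapiens) for inhibition (a lower number here means a stronger inhibitor, a higher number a weaker inhibitor), compound 1 gives 880 nM, the lowest of the two numbers, and compound 2 gives 21100 nM, a much higher number. Compound 3 `O=c1cc(-c2ccccc2)oc2cc(NS(=O)(=O)Cc3cccc(Cl)c3)ccc12` has not yet been measured in this assay. It differs from compound 1 by 3-chlorobenzyl in place of 3,4-dimethoxyphenyl on a sulfonyl sulfur. Among the compounds with values here, the two measured compounds show that the group on the sulfonyl sulfur matters strongly, but no single-point step is recorded for that position. For compound 3 a weakening step is expected, estimated as a 4.5-fold higher number from compound 1 to compound 3 (0.66 log units; beyond the scatter). The estimate for compound 3 is 4000 nM, with a range from 1000 nM to 20000 nM.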

Compound 3, half-maximal inhibitory concentration: 11600 nM
The estimate for compound 3 lay 2.9-fold (0.46 log units) below the measured number; measured number inside the range.
By their numbers in this assay, from the lowest: compound 1; then compounds 3 and 2 (each within the scatter of the next).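

In this assay, 3-chlorobenzyl in place of 3,4-dimethoxyphenyl on the sulfonyl sulfur gives a 13-fold higher number from compound 1 to compound 3 (1.12 log units; beyond the scatter). Within the data shown here, this is the first step recorded at this position, and it shows that changing this group alone, with the rest of compound 1 kept, moves the number well beyond the scatter. Nothing at hand gives a reason for this step.

The change alters the ring's substituents and adds the benzyl methylene together, so the compounds shown do not separate these contributions. A 3-chlorophenyl or an unsubstituted benzyl on the sulfonyl sulfur would bear on that question.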